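The source may report more compounds than this note shows. Statements on the series, on what has been measured and on what is new or still open speak of the compounds shown alone.

Measured compounds:
- Compound 1, `COc1ccc(COc2ccc(-c3nn(CCC#N)c(=O)o3)cc2)cc1`: 16000 nM
- Compound 2, `COc1ccc(COc2ccc(-c3nn(CCC#N)c(=S)o3)cc2)cc1`: 4800 nM

Both compounds were tested in an assay for inhibition of Amine oxidase [flavin-containing] A (Rattus norvegicus); a higher number here means a weaker inhibitor, a lower number a stronger inhibitor. Compound 1 gives 16000 nM in this assay, while compound 2 gives 4800 nM. Of the two numbers, compound 2 has the lower one, and the gap to compound 1 is larger than the usual scatter of repeated measurements, so compound 2 is the stronger inhibitor of this pair.

The next compound, compound 3, has the structure `N#CCCn1nc(-c2ccc(OCc3ccc([N+](=O)[O-])cc3)cc2)oc1=S`. It differs from compound 2 in one place: nitro in place of methoxy on an aromatic carbon. In words, a nitro group takes the place of a methoxy group on an aromatic carbon.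

Going by the values given here, no pair of measured compounds shows this particular exchange, so there is no direct guide to its effect. The expectation is therefore cautious: a small step, if any, from compound 2 to compound 3, leaning toward a slightly lower number, so that the expected step is a 1.4-fold lower number from compound 2 to compound 3 (0.14 log units; within the scatter). On that basis compound 3 is estimated at 3500 nM in this assay, with a plausible range from 1200 nM to 10000 nM.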

Compound 3, half-maximal inhibitory concentration: 2600 nM
Beside the measured number, compound 3's estimate is 1.3-fold (0.13 log units) above it; the range from low to high includes it.
By their numbers in this assay, from the lowest: compounds 3 and 2 (each within the scatter of the next); then compound 1.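

Nitro in place of methoxy on the aromatic carbon, the change that reads 4-methoxyphenyl to 4-nitrophenyl, gives a 1.8-fold lower number from compound 2 to compound 3 (0.27 log units; within the scatter) in this assay. Going by these compounds alone, this pair is the first look at this position, and it shows that the exchange, which adds one heavy atom and one hydrogen-bond acceptor by the count, leaves the number within the usual scatter of repeated measurements, so the two groups cannot be told apart in this assay. Nothing measured alongside these compounds speaks to why their numbers sit so close.

The compounds shown leave open whether a different group at this spot, such as an amine, a carboxylic acid or a longer alkoxy chain, would move the number beyond the scatter. They also leave open whether the same exchange of methoxy for nitro on the core of compound 1 would give a step of similar size, since this change has been seen on one core only.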